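A New Chain in Place of the Methoxycarbonyl Group

This account rests on a few compounds, and the source may have more. Where it says the series, first, only, none or still open, it means among the compounds named here.

Measured so far:
- Compound 1, `CC(C)(C)c1ccc2nc(N)sc2c1`: in a functional assay on the whole organism with Rattus norvegicus as the target (a lower number here means that less compound is needed, a higher number that more compound is needed for the effect), compound 1 gives 4 mg/kg.
- Compound 2, `COC(=O)Cn1c(=N)sc2cc(OC(F)(F)F)ccc21`: in this assay compound 2 reaches only a limit, > 10 mg/kg.

Of the compounds shown here, two have been tested in this assay, and they sit apart. Compound 1 gives a real number. Compound 2 gives no number, only a limit: its value is the limit of > 10 mg/kg in this assay, at which 1 of the 2 values shown sits, meaning the dose that would produce the half-maximal effect was not reached within the range tested. Where compound 2 truly stands is therefore open; all that is known is that it needs more compound than the limit.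

Compound 3, `C[S+]([O-])CCCn1c(=N)sc2cc(OC(F)(F)F)ccc21`, keeps the core of compound 2 and changes only the chain carried on the aromatic nitrogen: a group of 5 heavy atoms (3 carbon, 1 oxygen, 1 sulfur; no ring) in place of a group of 4 heavy atoms (2 carbon, 2 oxygen; no ring), on a saturated chain carbon bound to an aromatic nitrogen. Within the data shown here, the data hold no measured pair that would show what such a swap does in this assay, so no direction can be read from them. The step expected from compound 2 to compound 3 is therefore a number no higher from compound 2 to compound 3 (the limit leaves the size open), none beyond the scatter. Compound 3 is expected to give about 10 mg/kg, within a range of 3 mg/kg to 30 mg/kg.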

Compound 3, dose for half-maximal effect: 2.3 mg/kg
Beside the measured number, compound 3's estimate is 4.3-fold (0.64 log units) above it; the measured number lies below the stated range.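

In this assay, putting the group of 5 heavy atoms in place of the methoxycarbonyl group, on a saturated chain carbon bound to an aromatic nitrogen, gives an at least 4.3-fold lower number from compound 2 to compound 3 (0.63 log units; beyond the scatter). Among these compounds, this is the first measured step at this place, and it shows that the chain on the aromatic nitrogen has a real bearing on the result, since a change here alone, with the shared core kept, turns a limit into a number. The true size of the step remains unknown and could be larger than the figure given, because compound 2 gives a limit and not a number: the limit of > 10 mg/kg in this assay, at which 1 of the 3 values shown sits.

As far as these compounds go, what remains open is which feature of the new chain goes with the lower number: its sulfur and oxygen unit, or its length, which a plain propyl chain, a longer chain with the same sulfur and oxygen unit, an amine or a carboxylic acid at this place could help separate. Compound 1 differs from compound 2 and compound 3 in more than one place, so whether the new chain would have a similar effect on the core of compound 1 is also unresolved.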